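Ring-amine substituents and type 1 receptor affinity

This account rests on a few compounds, and the source may have more. Where it says the series, first, only, none or still open, it means among the compounds named here.

Measured in an assay on AV12 cells for binding affinity to Neuropeptide Y receptor type 1 (Homo sapiens); on this read-out higher numbers stand for weaker inhibition and lower numbers for stronger inhibition:
compound 1 `Cc1cccc2c1nc(COc1ccc(Cl)cc1)n2CCCC1CCNCC1` gives 335 nM
compound 2 `Cc1cccc2c1nc(COc1ccc(Cl)cc1)n2CCCC1CCN(C)CC1` gives 52 nM
compound 3 `Cc1cccc2c1nc(COc1ccc(Cl)cc1)n2CCCC1CCN(Cc2ccccc2)CC1` gives 109 nM

Compound 3 holds the second highest number of the three: a 2.1-fold higher number from compound 2 to compound 3 (0.32 log units; beyond the scatter), while a 3.1-fold lower number from compound 1 to compound 3 (0.49 log units; beyond the scatter). Compound 4 `CCOC(=O)CN1CCC(CCCn2c(COc3ccc(Cl)cc3)nc3c(C)cccc32)CC1` differs from compound 3 by ethoxycarbonyl in place of phenyl on a saturated chain carbon bound to an amine nitrogen in a ring. Among the measured compounds shown here, no measured step tests an ethoxycarbonyl here; the nearest is the phenyl step, which raised the number modestly, and both substituted amines sit well under compound 1 (a 6.4-fold lower number from compound 1 to compound 2 (0.81 log units; beyond the scatter)). The change is therefore expected to move this assay little, with a modest shift in either direction possible, so compound 4 is estimated at 100 nM (range 40 nM to 300 nM), meaning an expected step of a 1.1-fold lower number from compound 3 to compound 4 (0.04 log units; within the scatter).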

Compound 4, inhibition constant: 427 nM
Compound 4: the middle estimate sits 4.3-fold (0.63 log units) below what was measured, outside the stated range (above it).
By their numbers in this assay, from the lowest: compound 2; then compound 3; then compounds 1 and 4 (each within the scatter of the next).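

In this assay, the gain seen on the ring amine nitrogen depends on the group: on the saturated chain carbon bound to that nitrogen, ethoxycarbonyl in place of phenyl gives a 3.9-fold higher number from compound 3 to compound 4 (0.59 log units; beyond the scatter), and in place of hydrogen gives an 8.2-fold higher number from compound 2 to compound 4 (0.91 log units; beyond the scatter). (Ethoxycarbonyl)methyl in place of hydrogen on the nitrogen gives a 1.3-fold higher number from compound 1 to compound 4 (0.11 log units; within the scatter), so substitution there does not by itself lower the number, as it does with methyl and benzyl. Nothing available explains this difference between the groups. On these data alone, whether the ester itself matters remains open: the matching carboxylic acid, an amide or a longer chain carrying the ester could separate these readings.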